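Adding a chloro group to compound 3 of a small pyrimidine series

The source may hold more compounds than are shown below. What is called first, only, known or untested is meant among the compounds shown, and "the series" means these compounds.

Of the compounds shown here, three measured so far share one core and differ in the group attached to it. Compound 1 `Nc1ccnc(SCCCCc2ccccc2)n1` gives 1000000 nM in an assay on isolated protein for inhibition of deoxycytidine kinase (Rattus norvegicus); a higher number here means a weaker inhibitor, a lower number a stronger inhibitor. Compound 2 `Nc1ccnc(Oc2ccc(Cl)cc2)n1` gives 5000000 nM in this assay. Compound 3 `Nc1ccnc(SCc2ccccc2)n1` gives 2800000 nM in this assay, the second highest of the three numbers: its gap to compound 2 lies within the usual scatter, while its gap to compound 1 is beyond it.

Compound 4 `Nc1ccnc(SCc2ccc(Cl)cc2)n1` has not been measured. It differs from compound 3 in one place: chloro in place of hydrogen on an aromatic carbon. Within the data shown here, no pair of measured compounds shows the effect of this exact change. Compound 2 carries a chloro group on a comparable ring, yet its value and that of compound 3 differ by less than the scatter, so no clear direction can be read from it.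

Compound 4 is therefore expected to stay close to compound 3, with a step of a 1.1-fold lower number from compound 3 to compound 4 (0.05 log units; within the scatter) that is estimated to fall within the scatter. The estimate for compound 4 is 2500000 nM, with a range from 800000 nM to 8000000 nM.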

Compound 4, half-maximal inhibitory concentration: 1000000 nM
Estimate against measurement, compound 4: 2.5-fold (0.40 log units) above, within the range that was stated.
By their numbers in this assay, from the lowest: compounds 1 and 4 (each within the scatter of the next); then compounds 3 and 2 (each within the scatter of the next).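

Among these compounds, putting chloro in place of hydrogen on an aromatic carbon gives a 2.8-fold lower number from compound 3 to compound 4 (0.45 log units; beyond the scatter) in this assay and so moves the number toward stronger inhibition, the first direct reading of this change. The step is modest and comes from a single pair of compounds, so it gives a direction for this one position on this one scaffold and no general rule. No separate measurement bears on why the number falls.

As far as these compounds go, whether fluoro, methoxy or an amine in the same place would move the number in the same direction remains open. Also open, from the compounds shown here alone, is whether chloro would give a similar step on the aromatic ring of compound 1, which carries a longer chain.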